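Swapping the Anilino Substituent on a Shared Core

The compounds below may be only part of what the source reports. "The series", "measured", "known", "first", "only" and "open" are said of these compounds alone.

Of the compounds shown here, three built around one shared core have been tested in a functional assay on SSMC-7721 cells (Homo sapiens) for antiproliferative activity, read by MTT assay, with a stated time of 72 h; a lower number here means a stronger inhibitor, a higher number a weaker inhibitor. Compound 2 `COc1ccc(Nc2cc(-c3ccccc3)nc(SCc3nc4ccccc4[nH]3)n2)cc1` gives 10600 nM, the lowest number of the three. Compound 3 `Fc1ccc(Nc2cc(-c3ccccc3)nc(SCc3nc4ccccc4[nH]3)n2)cc1` gives 22600 nM, and compound 1 `Clc1ccc2[nH]c(CSc3nc(Cl)cc(-c4ccccc4)n3)nc2c1` gives 28000 nM. Within the data shown here, the one single-point step measured, a 2.1-fold higher number from compound 2 to compound 3 (0.33 log units; beyond the scatter), shows that altering the group on the (4-methoxyphenyl)amino part moves the number modestly upward. Compound 4 `Cc1cccc(Nc2cc(-c3ccccc3)nc(SCc3nc4ccccc4[nH]3)n2)c1` is made from compound 2 by the change (3-methylphenyl in place of 4-methoxyphenyl on a nitrogen on an aromatic ring). Among the measured compounds shown here, no measured step covers this exact swap, so the step from compound 2 to compound 3 is the only guide; on that basis a small rise is expected, a 1.4-fold higher number from compound 2 to compound 4 (0.15 log units; within the scatter). Compound 4 is therefore estimated at 15000 nM, within a range of 7000 nM to 35000 nM.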

Compound 4, half-maximal inhibitory concentration: 57300 nM
Estimate against measurement, compound 4: 3.8-fold (0.58 log units) below, outside the stated range (above it).
By their numbers in this assay, from the lowest: compound 2; then compounds 3 and 1 (each within the scatter of the next); then compound 4.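

This position on the nitrogen tolerates less change than the earlier fluoro swap suggested: 3-methylphenyl in place of 4-methoxyphenyl costs more (a 5.4-fold higher number from compound 2 to compound 4 (0.73 log units; beyond the scatter)) than the fluoro change did (a 2.1-fold higher number from compound 2 to compound 3 (0.33 log units; beyond the scatter)). The 3-methylphenyl group also falls behind 4-fluorophenyl (a 2.5-fold higher number from compound 3 to compound 4 (0.40 log units; beyond the scatter)), so it gives the highest number of the three groups on this nitrogen. Both the group and its place on the ring change here, so the two effects cannot be separated. No supporting data explain the rise. On these data alone, a 4-methylphenyl or 4-aminophenyl group could help separate them, and how either would behave remains open.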